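This account rests on a few compounds, and the source may have more. Where it says the series, first, only, none or still open, it means among the compounds named here.

Of the compounds shown here, three built on one shared core have been tested in a functional assay on MDA-MB-231 cells (Homo sapiens) for antiproliferative activity, read by CCK-8 assay, with a stated time of 72 h; on this read-out higher numbers stand for weaker inhibition and lower numbers for stronger inhibition. Compound 1 `Cc1cc(Nc2cc(N3CCN(C)CC3)nc(Nc3ccc([N+](=O)[O-])cc3)n2)n[nH]1` gives 84.4 nM in this assay. Compound 2 `Cc1cc(Nc2cc(N3CCN(C)CC3)nc(Nc3ccc(Cl)cc3)n2)n[nH]1` gives 138 nM in this assay, and compound 3 `Cc1cc(Nc2cc(N3CCN(C)CC3)nc(Nc3cccc([N+](=O)[O-])c3)n2)n[nH]1` gives 114 nM in this assay.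

Compound 2 is related to compound 1 by chloro in place of nitro on an aromatic carbon and that change gave a 1.6-fold higher number from compound 1 to compound 2 (0.21 log units; within the scatter). Compound 3 differs from compound 1 in the way its atoms are joined rather than in which atoms it holds: 3-nitrophenyl in place of 4-nitrophenyl on a nitrogen on an aromatic ring with a step of a 1.4-fold higher number from compound 1 to compound 3 (0.13 log units; within the scatter). Between compound 2 and compound 3 the step is a 1.2-fold lower number from compound 2 to compound 3 (0.08 log units; within the scatter). None of these three numbers can be ranked against the others.

Compound 4 `Cc1cc(Nc2cc(N3CCN(C)CC3)nc(Nc3cccc(Cl)c3)n2)n[nH]1` has not yet been measured. It differs from compound 3 by chloro in place of nitro on an aromatic carbon. This is the same kind of change as the one from compound 1 to compound 2, but not the same: in compound 1 the leaving group sits para to a large group, while in compound 3 it sits meta to a large group, and the cores of compound 1 and compound 3 themselves differ as described above.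

Within the data shown here, with only one earlier example to rest on, the step from compound 3 to compound 4 is expected to be small, about a 1.6-fold higher number from compound 3 to compound 4 (0.20 log units; within the scatter), because the earlier exchange gave a 1.6-fold higher number from compound 1 to compound 2 (0.21 log units; within the scatter). Compound 4 is therefore estimated at 180 nM in this assay, with a likely range from 90 nM to 360 nM.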

Compound 4, half-maximal inhibitory concentration: 56.4 nM
Compound 4: middle estimate off by 3.2-fold (0.50 log units), on the high side; the whole stated range lies above it.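

Going from 3-nitrophenyl to 3-chlorophenyl gave a 2.0-fold lower number from compound 3 to compound 4 (0.31 log units; beyond the scatter), and going from 4-chlorophenyl to 3-chlorophenyl gave a 2.4-fold lower number from compound 2 to compound 4 (0.39 log units; beyond the scatter), whereas 3-chlorophenyl in place of 4-nitrophenyl gave a 1.5-fold lower number from compound 1 to compound 4 (0.18 log units; within the scatter). In this assay, among these compounds, the step seen when chloro replaced nitro on one parent compound therefore could not simply be copied to the other, as the two steps differ by more than repeat measurements would normally give: the same change on two cores in this assay, a 1.6-fold higher number (0.21 log units; within the scatter) from compound 1 to compound 2 and a 2.0-fold lower number (0.31 log units; beyond the scatter) from compound 3 to compound 4, 3.3-fold (0.52 log units) apart, beyond the scatter of two such steps This comparison rests on only two pairs of compounds, so it shows that this exchange did not carry over between these two parents, but it does not show why, or how the exchange would behave elsewhere.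

The compounds shown leave open how other groups on the same aromatic carbon would behave, such as fluoro, methoxy, a nitrile or an amine, and whether any of them would follow the chloro of compound 4 or the nitro of compound 3. Also open, going by these compounds, is whether the exchange of nitro for chloro gives the same step once another part of the shared core is changed.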